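The source may hold more compounds than are shown below. What is called first, only, known or untested is meant among the compounds shown, and "the series" means these compounds.

Three compounds share one core. Compound 1 is drawn as `Cc1cccc(-c2cnc(N)nc2-c2ccccc2)c1`. Compound 2 is drawn as `Nc1ncc(-c2ccc(Cl)cc2)c(-c2ccccc2)n1`. Compound 3 is drawn as `CCCC(=O)Nc1ncc(-c2cccc(Cl)c2)c(-c2ccccc2)n1`. In an assay on CHO cells for displacement of a labelled ligand from adenosine receptor A1 (Homo sapiens), read by scintillation counting, with a stated time of 1 h, tested at 1 uM (a lower number here means less inhibition, a higher number more inhibition at the concentration tested (going by the name of the read-out)), compound 1 reaches the limit of the assay at > 80%. Compound 2 gives 41% in this assay. Compound 3 likewise sits at the limit of the assay, reported as > 80%, so only a limit and no number is known for it, which is the limit of > 80% in this assay, at which 2 of the 3 values shown sit. Compound 4, `Clc1cccc(-c2cnc(Nc3ccccc3)nc2-c2ccccc2)c1`, has not yet been measured in this assay. It differs from compound 3 in one place: phenyl in place of propylcarbonyl on a nitrogen on an aromatic ring. From the limit at which compound 3 sits, any step can only read as a drop. Compound 2 gives 41% in this assay, so a drop of that size for compound 4 cannot be excluded. The step from compound 3 to compound 4 is expected to be a number at least 5 percentage points lower from compound 3 to compound 4 (that floor lies within the scatter). Compound 4 is estimated at 75%, within 50% to 90%.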

Compound 4, a percentage reported as inhibition, at one concentration (the size of the read-out at that concentration, not a potency): 34%
Compound 4: the middle estimate sits 41 percentage points above what was measured; measured number below the stated range.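

The nitrogen on an aromatic ring proves to be a position where the group matters: phenyl in place of propylcarbonyl gives a number at least 46 percentage points lower from compound 3 to compound 4 (beyond the scatter) in this assay. Going by these compounds alone, this is the first step at this position that can be read, and it is large. It gives only a floor, as compound 3 is known only as a limit: the limit of > 80% in this assay, at which 2 of the 4 values shown sit.

Going by these compounds, whether the drop follows from the arrival of the phenyl ring or from the departure of the carbonyl stays open. A benzoyl group or a plain ethyl chain on the same nitrogen would bear on that question.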